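Swapping a hexyl for a benzyl on a uridine diphosphate analogue

The source may hold more compounds than are shown below. What is called first, only, known or untested is meant among the compounds shown, and "the series" means these compounds.

Three measured compounds share a uridine diphosphate scaffold and were tested in an in vitro functional assay on 1321-N1 cells for agonist activity at P2Y purinoceptor 6 (Homo sapiens); a lower number here means that less compound is needed, a higher number that more compound is needed for the effect. Compound 1 `O=c1ccn([C@@H]2O[C@H](COP(=O)(O)OP(=O)(O)O)C[C@H]2O)c(=O)[nH]1` gives 2500 nM. Compound 3 `N[C@@H]1[C@H](O)[C@@H](COP(=O)(O)OP(=O)(O)O)O[C@H]1n1ccc(=O)[nH]c1=O` gives 3900 nM. Compound 2 `CCCCCCSc1ccn([C@@H]2O[C@H](COP(=O)(O)OP(=O)(O)O)[C@@H](O)[C@H]2O)c(=O)n1` gives 4900 nM, which is the highest of the three numbers; its gap to compound 3 and its gap to compound 1 both lie within the usual scatter of this assay, so the three cannot be ranked against one another.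

The next compound keeps the sugar and diphosphate of compound 2 and changes only the sulfur-linked chain. Compound 4 `O=c1nc(SCc2ccccc2)ccn1[C@@H]1O[C@H](COP(=O)(O)OP(=O)(O)O)[C@@H](O)[C@H]1O` differs from compound 2 by phenyl in place of pentyl on a saturated chain carbon bound to a sulfur. Within the data shown here, no measured pair in this set shows such a change, so there is no earlier step to lean on, and the three measured values sit close together without a clear trend.

With nothing in the measured data pointing either way, the change from compound 2 to compound 4 is expected to give no step beyond the scatter, so the estimated step is a 1.2-fold lower number from compound 2 to compound 4 (0.09 log units; within the scatter). The value for compound 4 in this assay is estimated at 4000 nM, with a likely range from 1000 nM to 16000 nM.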

Compound 4, half-maximal effective concentration: 800 nM
Compound 4: middle estimate off by 5.0-fold (0.70 log units), on the high side; measured number below the stated range.
By their numbers in this assay, from the lowest: compound 4; then compounds 1, 3 and 2 (each within the scatter of the next).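

Among these compounds, exchanging hexyl for benzyl on the sulfur gives a 6.1-fold lower number from compound 2 to compound 4 (0.79 log units; beyond the scatter) in this assay, and this is the first step in the set that can be read as a change in one place. Among the compounds shown here, it shows that the group carried on the sulfur-bound chain carbon can shift the number well beyond the scatter, something the earlier compounds could not show, as they offered no single-place comparison. The pair also shows that a phenyl ring in place of pentyl at this carbon lowers the number here, but this rests on one step, and nothing measured explains why it happens.

The compounds shown leave open whether the phenyl ring itself matters or whether other groups at this place would do as well, such as a cyclohexylmethyl chain, which keeps a ring but is not aromatic, or a pyridylmethyl group, which has nitrogen in the ring. They also leave open how a longer link such as phenylethyl, or a chlorine or methoxy group on the benzyl ring, would change the number.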